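Chloro for Hydrogen on a Purine-Like Core: Cytotoxicity in Colon Cancer Cells

The source may report more compounds than this note shows. Statements on the series, on what has been measured and on what is new or still open speak of the compounds shown alone.

Measured so far:
- compound 1, `ClCc1cccc(Cn2cnc3ncnc(Cl)c32)c1`: 1940 nM
- compound 2, `ClCc1cccc(Cn2cnc3c(Cl)ncnc32)c1`: 2180 nM
- compound 3, `ClCc1cccc(Cn2cnc3c(Cl)nc(Cl)nc32)c1`: 2390 nM

All three compounds were tested in a functional assay on HCT-15 cells (Homo sapiens) for cytotoxicity, read by sulforhodamine B assay, with a stated time of 48 h; a higher number here means a weaker inhibitor of growth, a lower number a stronger inhibitor of growth. Compound 1 and compound 2 are built from the same atoms joined differently; the difference between the two cores is not broken down here, and their values in this assay lie within the scatter of each other. Compound 3 is compound 2 with one extra group, the change being (chloro in place of hydrogen on an aromatic carbon). That step gave a 1.1-fold higher number from compound 2 to compound 3 (0.04 log units; within the scatter), so adding the chloro group at this place left the growth-inhibiting power of the compound essentially where it was.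

The unmeasured compound 4, `ClCc1cccc(Cn2cnc3nc(Cl)nc(Cl)c32)c1`, stands to compound 1 as compound 3 stands to compound 2: the change is chloro in place of hydrogen on an aromatic carbon. The place of the change is described in the same words in both cases, so this is the same change made on the other core.

Because the earlier step was a 1.1-fold higher number from compound 2 to compound 3 (0.04 log units; within the scatter) and because compound 1 gives 1940 nM in this assay, compound 4 is expected to land close to compound 1, with a step of about a 1.1-fold higher number from compound 1 to compound 4 (0.03 log units; within the scatter). The estimate for compound 4 in this assay is 2100 nM, expected to fall between 1200 nM and 3800 nM. This rests on a single earlier example of the change, so the confidence is modest.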

Compound 4, concentration for 50% growth inhibition: 950 nM
Estimate against measurement, compound 4: 2.2-fold (0.34 log units) above, and the stated range ends above it.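

In this assay, chloro in place of hydrogen on an aromatic carbon, here between two ring nitrogen atoms, gave a 2.0-fold lower number from compound 1 to compound 4 (0.31 log units; beyond the scatter), so on the core of compound 1 this single change moved the number by more than repeated measurements usually do. Set beside the same change on the other core, however, the two steps cannot be told apart, even though one lies within the scatter and the other beyond it: the same change on two cores in this assay, a 1.1-fold higher number (0.04 log units; within the scatter) from compound 2 to compound 3 and a 2.0-fold lower number (0.31 log units; beyond the scatter) from compound 1 to compound 4, 2.2-fold (0.35 log units) apart, within the scatter of two such steps. Among these compounds, this shows neither that the core alters what the chloro group does nor that the change carries over unaltered from one core to the other, since each core offers only one pair of compounds, in a single cell line, and a larger gap or more pairs would be needed to settle the matter either way.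

The compounds shown leave open whether a group other than chloro, such as an amine, a methoxy group or a methyl group, would move the number in the same direction at this place on either core. They also leave open whether the lower number of compound 4 would hold in cell types other than this one.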